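A few compounds are considered here, and "the series" means these few. Any claim that something is new, unique, unknown or untested is made for them only; others in the source may bear on it.

Compound 1 `Cc1c(NC(=O)COc2ccc(/C=C3\SC(=O)NC3=O)cc2)c(=O)n(-c2ccccc2)n1C`, compound 2 `O=C(COc1ccc(/C=C2\SC(=O)NC2=O)cc1)Nc1nc2ccccc2s1` and the still unmeasured compound 3 `Cc1cc(NC(=O)COc2ccc(/C=C3\SC(=O)NC3=O)cc2)no1` share one core and were examined in a functional assay on K562 cells (Homo sapiens) for cytotoxicity, read by sulforhodamine B assay, with a stated time of 48 h; on this read-out higher numbers stand for weaker inhibition of growth and lower numbers for stronger inhibition of growth. In this assay compound 1 returns only a limit, < 100000 nM. In this assay compound 2 likewise returns only a limit, < 100000 nM. Among the measured compounds shown here, both results rest at the same boundary of the measurement (the limit of < 100000 nM in this assay, at which 2 of the 2 values shown sit), so compound 2 stands where the one other measured compound stands, with no number to separate them. The change toward compound 3 is 5-methyl-1,2-oxazol-3-yl in place of 1,3-benzothiazol-2-yl on an amide-type nitrogen. For the measured compounds named here, no measured step between compounds that differ in a single place exists, so nothing shows how this assay answers to an exchange of the group on the amide-type nitrogen; compound 1 and compound 2 carry different groups there and both give the same limit. For compound 3 the expected step is a step that the limit leaves unreadable from compound 2 to compound 3, not beyond the scatter. Compound 3 is estimated at 30000 nM, between 5000 nM and 100000 nM.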

Compound 3, concentration for 50% growth inhibition: 2750 nM
The estimate for compound 3 lay 11-fold (1.04 log units) above the measured number; measured number outside the range, below it.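

Among the compounds shown here, no step from compound 2 to compound 3 can be read in this assay, because compound 2 returns only a limit: the limit of < 100000 nM in this assay, at which 2 of the 3 values shown sit. The compounds shown leave open how 5-methyl-1,2-oxazol-3-yl and 1,3-benzothiazol-2-yl on the amide-type nitrogen truly compare.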